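Chloro in place of ethyl: a modest gain expected

This account rests on a few compounds, and the source may have more. Where it says the series, first, only, none or still open, it means among the compounds named here.

In a functional assay on K562 cells (Homo sapiens) for inhibition, read by CCK-8 assay, with a stated time of 72 h (a higher number here means a weaker inhibitor, a lower number a stronger inhibitor), compound 1 `O=C(/C=C/c1cccnc1)NCCCCCCc1cccc(S(=O)(=O)Nc2ccccc2)c1` gives 0.88 nM and compound 2 `Cc1ccccc1NS(=O)(=O)c1cccc(CCCCCCNC(=O)/C=C/c2cccnc2)c1` gives 0.456 nM while compound 3 `CCc1ccc(NS(=O)(=O)c2cccc(CCCCCCNC(=O)/C=C/c3cccnc3)c2)cc1` gives 3.89 nM as the highest number of the three, which makes it the weakest inhibitor here. Within the data shown here, compound 4 `O=C(/C=C/c1cccnc1)NCCCCCCc1cccc(S(=O)(=O)Nc2ccc(Cl)cc2)c1` is unmeasured and carries chloro in place of ethyl on an aromatic carbon and no measured compound holds chloro. The nearest guide is the step of a 4.4-fold higher number from compound 1 to compound 3 (0.65 log units; beyond the scatter) for ethyl in place of hydrogen on an aromatic carbon. Methyl in place of hydrogen gave a 1.9-fold lower number from compound 1 to compound 2 (0.29 log units; within the scatter) and the swap of 2-methylphenyl for 4-ethylphenyl gave an 8.5-fold higher number from compound 2 to compound 3 (0.93 log units; beyond the scatter) as the largest step seen. Losing ethyl may recover part of that ground, so a modest step of a 2.2-fold lower number from compound 3 to compound 4 (0.33 log units; beyond the scatter) is expected toward a stronger inhibitor. For compound 4 the estimated value is 1.8 nM with an expected range from 0.6 nM to 5.5 nM in this measurement.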

Compound 4, half-maximal inhibitory concentration: 6.41 nM
Compound 4: middle estimate off by 3.6-fold (0.55 log units), on the low side; measured number outside the range, above it.
By their numbers in this assay, from the lowest: compounds 2 and 1 (each within the scatter of the next); then compounds 3 and 4 (each within the scatter of the next).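

In this assay, chloro in place of ethyl at this place, para to a large group, leaves the number within the scatter (a 1.6-fold higher number from compound 3 to compound 4 (0.22 log units; within the scatter)), so these two groups cannot be told apart here. Chloro in place of hydrogen costs clearly more (a 7.3-fold higher number from compound 1 to compound 4 (0.86 log units; beyond the scatter)), and the step from the 2-methylphenyl of compound 2 is the largest seen so far (a 14-fold higher number from compound 2 to compound 4 (1.15 log units; beyond the scatter)), so both groups at this place read weaker than hydrogen. Nothing available explains this result. Still open, as far as these compounds go, is how an amine, a carboxylic acid or a methoxy group at this place would compare with chloro and ethyl.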